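Replacing 4-chlorophenyl with 3-cyanophenyl in compound 2

This account rests on a few compounds, and the source may have more. Where it says the series, first, only, none or still open, it means among the compounds named here.

Among the measured compounds shown here, in a functional assay (strain AB) with Danio rerio as the target, read by microscopy, with a stated time of 1 h (on this read-out higher numbers stand for an effect only at larger amounts of compound and lower numbers for an effect already at smaller amounts), compound 2 `CCN1CCc2c(sc(NC(=O)Nc3ccc(Cl)cc3)c2C(N)=O)C1` gives 3120 nM, the higher of the two numbers measured so far. Compound 3 `CC(C)(C)OC(=O)CCN1CCc2c(sc(NC(=O)Nc3ccc(Cl)cc3)c2C(N)=O)C1` gives 1100 nM, which makes it the nearest neighbour of compound 2 on this scale. Compound 1 `CCN1CCc2c(sc(NC(=O)NCC3CCCO3)c2C(N)=O)C1` gives > 25000 nM, which is a limit of this assay and not a number.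

Compound 4 `CCN1CCc2c(sc(NC(=O)Nc3cccc(C#N)c3)c2C(N)=O)C1` carries 3-cyanophenyl in place of 4-chlorophenyl on the amide-type nitrogen, a change counted as 3-cyanophenyl in place of 4-chlorophenyl on an amide-type nitrogen. Two measured steps are available. For the measured compounds named here, the one at this same nitrogen, an at least 8.0-fold lower number from compound 1 to compound 2 (0.90 log units; beyond the scatter), bears on it most directly, although the group replaced there was (oxolan-2-yl)methyl, so it shows only that a change at this nitrogen can move the number. The other, a 2.8-fold lower number from compound 2 to compound 3 (0.45 log units; beyond the scatter), lies on a saturated chain carbon, two bonds along the chain from an amine nitrogen in a ring, and so bears on compound 4 only weakly. Going by the values given here, no measured compound carries 3-cyanophenyl, which leaves the direction uncertain. The expected change is a modest one toward a higher number, a 1.6-fold higher number from compound 2 to compound 4 (0.20 log units; within the scatter). Compound 4 is estimated at 5000 nM, with an expected range of 1500 nM to 17000 nM.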

Compound 4, half-maximal effective concentration: 10300 nM
Compound 4: the middle estimate sits 2.1-fold (0.31 log units) below what was measured; the measured number falls inside the stated range.
By their numbers in this assay, from the lowest: compound 3; then compound 2; then compound 4. At a limit, above all of these: compound 1.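

In this assay, the choice of aromatic group on the amide-type nitrogen matters in its own right: a 3.3-fold higher number from compound 2 to compound 4 (0.52 log units; beyond the scatter). The earlier step at this nitrogen had replaced (oxolan-2-yl)methyl, so it could not show that exchanging one substituted phenyl group for another also moves the number beyond the scatter. Compound 4 still keeps a benefit over the starting group, an at least 2.4-fold lower number from compound 1 to compound 4 (0.38 log units; beyond the scatter), though this is a smaller step than the one printed for 4-chlorophenyl, an at least 8.0-fold lower number from compound 1 to compound 2 (0.90 log units; beyond the scatter), and compound 1 stands at a limit and not at a number: the limit of > 25000 nM in this assay, at which 1 of the 4 values shown sits.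

The compounds shown do not separate the effect of the nitrile from that of the changed ring position and the loss of chlorine, a question that 3-chlorophenyl, 4-cyanophenyl or plain phenyl on the same nitrogen would address. They also leave open whether the tert-butoxycarbonyl chain on the ring amine, seen so far only with 4-chlorophenyl, would shift the number in the same direction alongside 3-cyanophenyl.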